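Swapping the aryl ring on the amide in a flavonol series

The source may hold more compounds than are shown below. What is called first, only, known or untested is meant among the compounds shown, and "the series" means these compounds.

Compound 1, `O=C(Nc1cccc(-c2oc3cc(-c4ccc(F)cc4)ccc3c(=O)c2O)c1)c1ccc(F)cc1`, in a functional assay on MCF7 cells (Homo sapiens) for antiproliferative activity, read by CCK-8 assay, with a stated time of 72 h (a higher number here means a weaker inhibitor, a lower number a stronger inhibitor), gives 8590 nM.
Compound 2, `O=C(Nc1cccc(-c2oc3cc(-c4ccc(F)cc4)ccc3c(=O)c2O)c1)c1ccc(Cl)cc1`, gives 4730 nM in this assay.
Compound 3, `O=C(Nc1cccc(-c2oc3cc(-c4ccc(F)cc4)ccc3c(=O)c2O)c1)c1ccc(F)cc1F`, gives 13500 nM in this assay.

All three share the same core and differ only in the aryl ring attached to the amide carbonyl. Compound 3 has the highest number of the three: its distance from compound 1 is a 1.6-fold higher number from compound 1 to compound 3 (0.20 log units; within the scatter), which stays within the scatter, while its distance from compound 2 is a 2.9-fold higher number from compound 2 to compound 3 (0.46 log units; beyond the scatter), which lies beyond it.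

Compound 4, `O=C(Nc1cccc(-c2oc3cc(-c4ccc(F)cc4)ccc3c(=O)c2O)c1)c1ccc(Br)cc1`, is the next step: 4-bromophenyl in place of 2,4-difluorophenyl on a carbonyl carbon. Within the data shown here, two measured steps bear on this. The step of a 2.9-fold higher number from compound 2 to compound 3 (0.46 log units; beyond the scatter) is, apart from bromine standing in for chlorine, the reverse of the present change, so running it backwards points toward a lower number. The step of a 1.8-fold lower number from compound 1 to compound 2 (0.26 log units; within the scatter), where chloro replaced fluoro on an aromatic carbon, gave a small drop that stayed within the scatter, so bromine in the same place is not expected to add much on its own.

Taken together, compound 4 is expected to give about 3500 nM, within a range of 1500 nM to 9000 nM. This estimate means a 3.9-fold lower number from compound 3 to compound 4 (0.59 log units; beyond the scatter), a modest expected improvement.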

Compound 4, half-maximal inhibitory concentration: 24000 nM
Compound 4: middle estimate off by 6.9-fold (0.84 log units), on the low side, outside the stated range (above it).
By their numbers in this assay, from the lowest: compounds 2, 1, 3 and 4 (each within the scatter of the next, the first and the last beyond it).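

Among these compounds, on the carbonyl carbon of the amide, the halogen on the ring matters more than the earlier compounds showed: bromo in place of chloro gives a clear loss (a 5.1-fold higher number from compound 2 to compound 4 (0.71 log units; beyond the scatter)), and bromo in place of fluoro also lies beyond the scatter (a 2.8-fold higher number from compound 1 to compound 4 (0.45 log units; beyond the scatter)). Chloro and fluoro had stayed within the scatter of each other, so these single-halogen rings do not follow a simple order. The 4-bromophenyl and 2,4-difluorophenyl rings cannot be told apart (a 1.8-fold higher number from compound 3 to compound 4 (0.25 log units; within the scatter)), and nothing available explains why bromo departs from chloro here.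

Every ring shown carries only halogen, so it remains open how a methyl group, a methoxy group or an amine at this ring would compare. Going by these compounds, an unsubstituted phenyl ring also remains open as a baseline for all four compounds.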